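From Benzyl to 4-Methoxyphenyl on the Shared Core

A few compounds are considered here, and "the series" means these few. Any claim that something is new, unique, unknown or untested is made for them only; others in the source may bear on it.

Going by the values given here, in a functional assay on MCF7 cells (Homo sapiens) for antiproliferative activity, read by MTT assay, with a stated time of 48 h (a higher number here means a weaker inhibitor, a lower number a stronger inhibitor), compound 3 `CCOC(=O)CNc1nc(NCc2ccccc2)ncc1[N+](=O)[O-]` gives 52400 nM, the only value in this set that is a number rather than a limit. Compound 1 `CCOC(=O)CNc1nc(Nc2ccccc2)ncc1[N+](=O)[O-]` sits at the limit of the assay, > 100000 nM. Compound 2 `CCOC(=O)CNc1nc(Nc2ccc(Cl)cc2)ncc1[N+](=O)[O-]` likewise reaches only the limit, > 100000 nM. Compound 4 `CCOC(=O)CNc1nc(Nc2ccc(OC)cc2)ncc1[N+](=O)[O-]` carries 4-methoxyphenyl in place of benzyl on a nitrogen on an aromatic ring. Among the compounds with values here, the steps that bear on this change are an at least 1.9-fold lower number from compound 1 to compound 3 (0.28 log units; that floor lies within the scatter) and an at least 1.9-fold lower number from compound 2 to compound 3 (0.28 log units; that floor lies within the scatter), both readable only down to the floor set by the limit of > 100000 nM in this assay, at which 2 of the 3 values shown sit. For compound 4 the return from benzyl to an aryl group on that nitrogen is expected to reverse this, with a step of a 2.1-fold higher number from compound 3 to compound 4 (0.32 log units; beyond the scatter) in this assay. Compound 4 is expected to give 110000 nM, within 40000 nM to 300000 nM, most likely again at the limit.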

Compound 4, half-maximal inhibitory concentration: > 100000 nM
Compound 4 was reported as a limit (the forecaster's own chance of this, stated with the estimate: 65%); the middle value lies beyond the limit too.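

The 4-methoxyphenyl group gives a third aryl group on this nitrogen that reaches the limit, which leaves compound 3, with benzyl, as the only one of the four with a number. The change from benzyl to 4-methoxyphenyl gives an at least 1.9-fold higher number from compound 3 to compound 4 (0.28 log units; that floor lies within the scatter) in this assay and so shows only a floor. The steps among the three aryl compounds cannot be read, because each of them stops at the same limit: the limit of > 100000 nM in this assay, at which 3 of the 4 values shown sit.

From the compounds shown here alone, it remains open whether a phenethyl group on this nitrogen would give a number, and how a carboxylic acid in place of the ethyl ester would read.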